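One More Fluorine on a Short Fluorinated Alcohol

The compounds below may be only part of what the source reports. "The series", "measured", "known", "first", "only" and "open" are said of these compounds alone.

Measured so far:
compound 1 `OCC(F)(F)C(F)(F)C(F)(F)C(F)F`, 1.89
compound 2 `CCCC(O)CF`, 0.74

Both compounds were measured in a physicochemical assay for lipophilicity, read by NMR; a lower number here means a more polar compound, a higher number a more lipophilic compound. Compound 1 gives 1.89, and compound 2 gives 0.74. Going by the values given here, compound 2 thus stands lowest of the two numbers, with compound 1 the only neighbour, and the gap between them is beyond the scatter of the method.

Compound 3 `CCCC(O)C(F)F` has not yet been measured. It differs from compound 2 in one place: fluoro in place of hydrogen on a saturated chain carbon bound to a fluorine atom and a saturated chain carbon. Among the compounds with values here, no measured pair here shows what such a single exchange does, so the expectation rests on the two numbers alone. A small upward step in this assay seems the likeliest outcome, though a step that stays within the scatter would not be surprising. The expected step is a number 0.26 log units higher from compound 2 to compound 3 (within the scatter). For compound 3 the estimate in this assay is 1, between 0.7 and 1.4.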

Compound 3, partition coefficient: 1.14
For compound 3 the middle estimate is 0.14 log units below the measured one; measured number inside the range.
By their numbers in this assay, from the lowest: compound 2; then compound 3; then compound 1.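

Going by these compounds alone, this is the first pair here that differs in one place, so a single exchange can now be read directly. In this assay, fluoro in place of hydrogen on a saturated chain carbon bound to a fluorine atom and a saturated chain carbon gives a number 0.40 log units higher from compound 2 to compound 3 (beyond the scatter), a modest step, but one that stands clear of the usual scatter of the method. Nothing available explains why the step has this size or direction.

Within the data shown here, a single pair gives only one reading, so it remains open whether the same exchange would give a similar step on a longer chain or at another carbon. Also open, as far as these compounds go, is how a trifluoromethyl group at this place would compare, or a nitrile, which would show whether this step is particular to fluoro.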